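Replacing 1H-pyrazol-3-yl with (methoxycarbonyl)amino on compound 2

The source may hold more compounds than are shown below. What is called first, only, known or untested is meant among the compounds shown, and "the series" means these compounds.

In an ADME assay on the whole organism for pharmacokinetics, with Rattus norvegicus as the target, at a dose of 2 mg/kg by the oral route (a lower number here means less compound in the circulation, a higher number more compound in the circulation at the dose given), compound 1 (`CN1C(=O)[C@@H](NC(=O)c2cc(Cc3ccccc3)on2)CCc2ccccc21`) gives 7 ng.h/mL, and compound 2 (`CN1C(=O)[C@@H](NC(=O)c2cc(Cc3ccccc3)on2)COc2ccc(-c3cc[nH]n3)cc21`) gives 600 ng.h/mL. Compound 2 thus holds the higher of the two numbers, and the gap between them lies well beyond the scatter. These two compounds differ in more than one place, so neither value shows what a single change does. Compound 3 (`COC(=O)Nc1ccc2c(c1)N(C)C(=O)[C@@H](NC(=O)c1cc(Cc3ccccc3)on1)CO2`) has (methoxycarbonyl)amino in place of 1H-pyrazol-3-yl on an aromatic carbon. Among the measured compounds shown here, no measured pair covers this swap, and the expectation starts from compound 2 at 600 ng.h/mL. A modest drop, only slightly beyond the scatter, is expected in this assay, and the estimated step is a 2.4-fold lower number from compound 2 to compound 3 (0.38 log units; beyond the scatter). This is an uncertain call. For compound 3 the estimated value is 250 ng.h/mL, with an expected range of 50 ng.h/mL to 1200 ng.h/mL.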

Compound 3, area under the concentration-time curve: 1100 ng.h/mL
Compound 3: middle estimate off by 4.4-fold (0.64 log units), on the low side; measured number inside the range.
By their numbers in this assay, from the lowest: compound 1; then compounds 2 and 3 (each within the scatter of the next).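

In this assay, putting (methoxycarbonyl)amino in place of 1H-pyrazol-3-yl on this aromatic carbon gives a 1.8-fold higher number from compound 2 to compound 3 (0.26 log units; within the scatter), so the two compounds cannot be told apart on this read-out. The five-membered aromatic ring is therefore not needed at this position to hold the number seen with compound 2, since a group with no ring serves as well in this single comparison. Nothing measured alongside these numbers accounts for the result. From the compounds shown here alone, whether an amine or a carboxylic acid on the same aromatic carbon would also leave the number in this range remains open. Compound 1 differs from compound 2 and compound 3 in more than one place, so which of those differences lies behind its much lower number also stays unresolved.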